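This account rests on a few compounds, and the source may have more. Where it says the series, first, only, none or still open, it means among the compounds named here.

For the measured compounds named here, in a functional assay on MCF7 cells (Homo sapiens) for cytotoxicity, read by MTT assay, with a stated time of 72 h (on this read-out lower numbers stand for stronger inhibition and higher numbers for weaker inhibition), compound 1 `O=C1c2c[n+]([O-])c3ccccc3c2C(=O)c2c1c1ccccc1n2CCCCn1ccnc1` gives 130 nM, the only exact number available so far. Compound 2 `CC1(C)OC[C@@H](Cn2cc(Cn3c4c(c5ccccc53)C(=O)c3c[n+]([O-])c5ccccc5c3C4=O)nn2)O1` reads > 1000 nM, which is a limit of the assay and not a number. Compound 3 `O=C1c2c[n+]([O-])c3ccccc3c2C(=O)c2c1c1ccccc1n2CCCCN1CCCCC1` has not yet been measured. It keeps the core of compound 1 and changes one group: piperidin-1-yl in place of 1H-imidazol-1-yl on a saturated chain carbon, four bonds along the chain from an aromatic nitrogen. In words, piperidin-1-yl stands in place of 1H-imidazol-1-yl on a saturated chain carbon, four bonds along the chain from an aromatic nitrogen. Going by the values given here, no measured pair of compounds differs in just one place, so the data offer no direct guide to this swap. In this assay, a small move toward weaker inhibition is expected, one that may not clearly exceed the usual scatter. The estimated change is a 1.5-fold higher number from compound 1 to compound 3 (0.19 log units; within the scatter). For compound 3 the expected value is 200 nM, with an estimated range from 60 nM to 700 nM.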

Compound 3, half-maximal inhibitory concentration: 150 nM
For compound 3 the middle estimate is 1.3-fold (0.12 log units) above the measured one; low and high end bracket the measured number.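

In this assay, for the compounds shown here, the swap gives a 1.2-fold higher number from compound 1 to compound 3 (0.06 log units; within the scatter), the first step that can be read at this position, on a saturated chain carbon, four bonds along the chain from an aromatic nitrogen. Compound 1 and compound 3 therefore read alike, so for this pair, the aromatic five-membered ring with 2 hetero atoms and the non-aromatic six-membered ring with 1 hetero atom cannot be told apart on this read-out. Nothing in the data shown accounts for this match.

On these data alone, it remains open whether a simple open-chain amine such as dimethylamino, a morpholin-4-yl ring or a carboxylic acid at this place would read the same, and what a longer chain would do. Whether the two groups also read alike on other cell types is open too.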